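A few compounds are considered here, and "the series" means these few. Any claim that something is new, unique, unknown or untested is made for them only; others in the source may bear on it.

Measured compounds:

Compound 1, `O=C(/C=C\Nc1ccc(F)cc1)c1cn(-c2ccccc2)nc1-c1ccc(F)cc1`, gives > 50000 nM, which is a limit of the assay rather than a number.
Compound 2, `COc1cc(N/C=C\C(=O)c2cn(-c3ccccc3)nc2-c2ccc(F)cc2)cc(OC)c1OC`, gives 32800 nM.
Compound 3, `O=C(/C=C\Nc1ccc(F)cc1)c1cn(-c2ccccc2)nc1-c1ccc(Cl)cc1`, gives > 50000 nM, which is again a limit of the assay and not a number.

All three were examined in an ADME assay on HaCaT cells (Homo sapiens) for antiproliferative activity, read by MTT assay, with a stated time of 48 h; on this read-out lower numbers stand for stronger inhibition and higher numbers for weaker inhibition. Compound 2 stands as the only one of the three to return an actual number; the other two sit at the limit of > 50000 nM in this assay, at which 2 of the 3 values shown sit. Because both ends of the pair sit at that limit, the step that the two limits leave unreadable from compound 1 to compound 3 cannot be read; its change is chloro in place of fluoro on an aromatic carbon.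

The difference between the core of compound 1 and the core of compound 2 is not broken down here.

Compound 4, `COc1cc(N/C=C\C(=O)c2cn(-c3ccccc3)nc2-c2ccc(Cl)cc2)cc(OC)c1OC`, has not yet been measured in this assay. For the measured compounds named here, it differs from compound 2 by chloro in place of fluoro on an aromatic carbon, the same change as the one from compound 1 to compound 3, at a place described in the same words.

Going by the values given here, since the only measured instance of this change is left unreadable by the two limits, there is no measured size to carry over. The estimate for compound 4 therefore leans on the value of compound 2, 32800 nM, and assumes a step within the usual scatter. The expected step of a 1.1-fold higher number from compound 2 to compound 4 (0.03 log units; within the scatter) is accordingly small. Compound 4 is expected to give about 35000 nM in this assay. Its expected range runs from 14000 nM to 90000 nM, with a fair chance that only a limit is returned.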

Compound 4, half-maximal inhibitory concentration: 46600 nM
Compound 4: middle estimate off by 1.3-fold (0.12 log units), on the low side; measured number inside the range.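

In this assay the change from 4-fluorophenyl to 4-chlorophenyl now has one instance that can be read, a 1.4-fold higher number from compound 2 to compound 4 (0.15 log units; within the scatter) on the core of compound 2. On that core the two compounds therefore cannot be told apart, and swapping one halogen for the other left the read-out where repeated measurements of the same compound might be expected to fall. This does not show that the change carries from one core to another, since the only other instance, from compound 1 to compound 3 on the core of compound 1, cannot be read, with both compounds sitting at a limit of the assay and not at a number: the limit of > 50000 nM in this assay, at which 2 of the 4 values shown sit.

The compounds shown leave open whether a different group on the same aromatic carbon, such as a methoxy, a nitrile, an amine or a carboxylic acid, would move the number beyond the scatter on the core of compound 2. They also leave open how the step from fluoro to chloro would read on a core where both partners return a number and where that number lies well away from the limit.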